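Chalcone series: aryl swap on the enone before measurement

The compounds below may be only part of what the source reports. "The series", "measured", "known", "first", "only" and "open" are said of these compounds alone.

Compound 1 `CC(C)(C)c1ccc(/C=C/C(=O)c2ccc(OCC(=O)N[C@H]3CCOC3=O)cc2)cc1` carries the shared core with a 4-(tert-butyl)phenyl on the enone. In a functional assay on PC-3 cells (Homo sapiens) for antiproliferative activity, read by MTT assay, with a stated time of 72 h (on this read-out higher numbers stand for weaker inhibition and lower numbers for stronger inhibition), compound 1 gives 10600 nM, the only numerical result so far in the series. Compound 2 `O=C(CNc1ccccc1Cl)N[C@H]1CCOC1=O` is the other compound with a result. In this assay compound 2 reaches only a limit of the assay, > 64000 nM, and no number. The limit of > 64000 nM in this assay, at which 1 of the 2 values shown sits, marks where one of the two results sits, so compound 1 stands alone as a measured number and cannot be ranked against compound 2. Within the data shown here, no pair of measured compounds that differ in a single place is available, so no measured step exists to lean on.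

Compound 3 `O=C(COc1ccc(C(=O)/C=C/c2cccc(F)c2)cc1)N[C@H]1CCOC1=O` is not yet measured in this assay. It differs from compound 1 in one place: 3-fluorophenyl in place of 4-(tert-butyl)phenyl on a double-bonded chain carbon bound to a double-bonded chain carbon. The 4-(tert-butyl)phenyl leaves and the 3-fluorophenyl enters on the double-bonded chain carbon bound to a double-bonded chain carbon. The step of a 1.5-fold higher number from compound 1 to compound 3 (0.18 log units; within the scatter) is expected to be modest, toward weaker inhibition, at the edge of the usual scatter. Compound 3 is expected in this assay to give 16000 nM, between 5000 nM and 50000 nM.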

Compound 3, half-maximal inhibitory concentration: 23200 nM
The estimate for compound 3 lay 1.5-fold (0.16 log units) below the measured number; low and high end bracket the measured number.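

In this assay, among these compounds, the swap to 3-fluorophenyl on a double-bonded chain carbon bound to a double-bonded chain carbon gives a 2.2-fold higher number from compound 1 to compound 3 (0.34 log units; beyond the scatter) and is the first measured step. It shows that this place on the enone responds to a change of aryl group, with the number moving beyond the usual scatter toward weaker inhibition, although the size of the step is modest. The change also leaves a measured number rather than a limit of the assay, with compound 3 at 23200 nM in this assay, but no measured property in these notes bears on the step, and no cause can be assigned to it.

This single step changes two things at once, the loss of the tert-butyl group and the entry of the fluorine, and a plain phenyl, a 4-fluorophenyl or a 3-(tert-butyl)phenyl at the same place would be needed to separate them. Going by these compounds, the response of this place to an aryl group carrying an amine, such as 4-(dimethylamino)phenyl, or a carboxylic acid, such as 4-carboxyphenyl, remains open.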